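Aryl Swap at the Cinnamate End of a Shared Core

The source may report more compounds than this note shows. Statements on the series, on what has been measured and on what is new or still open speak of the compounds shown alone.

Compound 1 `COc1cc(OC)c(OC)cc1/C=C/COC(=O)/C=C/c1ccc(F)cc1` and compound 2 `COc1cc(OC)c(OC)cc1/C=C/COC(=O)/C=C/c1ccccc1Cl` share one core and differ only in the aryl group at the far end of the ester chain. In a functional assay on the whole organism (strain Kunming) with Mus musculus as the target, with a stated time of 0.5 h, at a dose of 300 mg/kg by the intraperitoneal route (a lower number here means a stronger effect, a higher number a weaker effect of the compound at the dose given), compound 1 gives 100%, and compound 2 gives 100%; the step of no change at the digits printed from compound 1 to compound 2 (within the scatter) shows that exchanging one halogenated phenyl for another left the read-out unmoved, so compound 2 stands level with compound 1 on the numbers shown.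

Compound 3 `COc1ccc(/C=C/C(=O)OC/C=C/c2cc(OC)c(OC)cc2OC)cc1` carries the change (4-methoxyphenyl in place of 2-chlorophenyl on a double-bonded chain carbon bound to a double-bonded chain carbon). Among the compounds with values here, the only measured step that bears on it is the one from compound 1 to compound 2, which was flat. Since the aryl swap already seen in compound 2 gave 100%, compound 3 is expected to show a step of no change at the digits printed from compound 2 to compound 3 (within the scatter) in this assay, none beyond the scatter. The value for compound 3 is estimated at 100%, between 80% and 100%.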

Compound 3, a percentage reported as activity, at one dose (the size of the read-out at that dose, not a potency): 100%
Estimate against measurement, compound 3: no gap at the digits printed, within the range that was stated.
By their numbers in this assay, from the lowest: compounds 1, 2 and 3 (each within the scatter of the next).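

In this assay, putting 4-methoxyphenyl in place of 2-chlorophenyl gives no change at the digits printed from compound 2 to compound 3 (within the scatter), and methoxy in place of fluoro on an aromatic carbon gives no change at the digits printed from compound 1 to compound 3 (within the scatter). The earlier step covered only an exchange of one halogenated phenyl for another, whereas this position, on a double-bonded chain carbon bound to a double-bonded chain carbon, now also holds a phenyl group with no halogen and with one hydrogen-bond acceptor, and the read-out stays level across all three compounds. No measurement offered here accounts for this flat result.

Going by these compounds, all three groups at this position are substituted phenyls, so it remains open whether a phenyl bearing an amine or a carboxylic acid, or a longer chain in place of the aryl group, would move the read-out. On these data alone, it also remains open whether the same flat result would hold at another dose or with a change in the shared core.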